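Compound 1 to compound 4: furan-2-yl for naphthalen-1-yl

The compounds below may be only part of what the source reports. "The series", "measured", "known", "first", "only" and "open" are said of these compounds alone.

In a functional assay on COLO 205 cells (Homo sapiens) for inhibition, read by sulforhodamine B assay, with a stated time of 48 h, tested at 50 uM (on this read-out lower numbers stand for less inhibition of growth and higher numbers for more inhibition of growth at the one concentration tested), the series stands as follows:

- compound 1 (`COc1cc(/C=C/C(=O)/C=C/c2cccc3ccccc23)ccc1OCc1cn(CCCCCOc2cc(=O)oc3ccccc23)nn1`) gives 40%
- compound 2 (`COc1cccc(/C=C/C(=O)/C=C/c2ccc(OCc3cn(CCOc4cc(=O)oc5ccccc45)nn3)c(OC)c2)c1`) gives 69%
- compound 3 (`COc1ccc(/C=C/C(=O)/C=C/c2ccc(OCc3cn(CCCOc4cc(=O)oc5ccccc45)nn3)c(OC)c2)cc1`) gives 53%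

Compound 1 holds the lowest of the three numbers. Compound 3 lies nearest above it and compound 2 furthest above it, both beyond the usual scatter.

The next compound to be read is compound 4 (`COc1cc(/C=C/C(=O)/C=C/c2ccco2)ccc1OCc1cn(CCCCCOc2cc(=O)oc3ccccc23)nn1`). Its difference from compound 1 is furan-2-yl in place of naphthalen-1-yl on a double-bonded chain carbon bound to a double-bonded chain carbon. The rest of the structure stays as in compound 1.

Going by the values given here, no pair of measured compounds differs in one place only, so the series offers no direct measure of what this exchange does. Compound 2 and compound 3 differ from compound 1 in more than one place, and their gaps to it cannot be assigned to a single change. The expectation is therefore weak. It rests on compound 1 (40%) sitting under both compound 3 (53%) and compound 2 (69%), which leaves more room upward than downward.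

A modest upward step near the edge of the scatter is expected, an estimated a number 10 percentage points higher from compound 1 to compound 4 (within the scatter) in this assay on this reasoning. Compound 4 is estimated at 50% with an expected range of 30% to 70% for its reading.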

Compound 4, percent growth inhibition at one concentration: 33%
Beside the measured number, compound 4's estimate is 17 percentage points above it; measured number inside the range.
By their numbers in this assay, from the lowest: compounds 4 and 1 (each within the scatter of the next); then compound 3; then compound 2.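

In this assay the series now has its first comparison that differs in one place only, on a double-bonded chain carbon bound to a double-bonded chain carbon: furan-2-yl in place of naphthalen-1-yl gives a number 7 percentage points lower from compound 1 to compound 4 (within the scatter) and so leaves the two readings indistinguishable. With the rest of the structure held as in compound 1, this position accepts an exchange of 10 heavy atoms in two six-membered aromatic rings of carbon only for 5 heavy atoms in one five-membered aromatic ring with 1 hetero atom and 1 hydrogen-bond acceptor, with no reading beyond the scatter. No measurement at hand offers an explanation for this result.

On these data alone, whether an aryl group carrying an amine or a carboxylic acid at this position would give a step beyond the scatter remains open, as does the outcome of this same exchange on a shared core with a shorter chain. Compound 2 and compound 3 differ from compound 1 in more than one place, so what sets their readings apart remains unassigned.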